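The source may hold more compounds than are shown below. What is called first, only, known or untested is meant among the compounds shown, and "the series" means these compounds.

Compound 1, `O=C1C=C(N2CCN(c3cccc(Cl)c3)CC2)C(=O)c2ccccc21`: 8300 nM
Compound 2, `Cc1cccc(N2CCN(C3=CC(=O)c4ccccc4C3=O)CC2)c1`: 7400 nM
Compound 3, `O=C1C=C(N2CCN(c3ccccc3Cl)CC2)C(=O)c2c(O)cccc21`: 2300 nM

Of the compounds shown here, three have been measured in a functional assay on DU-145 cells (Homo sapiens) for inhibition, read by MTT assay, with a stated time of 72 h; on this read-out higher numbers stand for weaker inhibition and lower numbers for stronger inhibition. Compound 1 `O=C1C=C(N2CCN(c3cccc(Cl)c3)CC2)C(=O)c2ccccc21` gives 8300 nM, compound 2 `Cc1cccc(N2CCN(C3=CC(=O)c4ccccc4C3=O)CC2)c1` gives 7400 nM, and compound 3 `O=C1C=C(N2CCN(c3ccccc3Cl)CC2)C(=O)c2c(O)cccc21` gives 2300 nM, the lowest of the three numbers.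

The change from compound 1 to compound 2 is methyl in place of chloro on an aromatic carbon. In this assay it gave a 1.1-fold lower number from compound 1 to compound 2 (0.05 log units; within the scatter), so the two numbers lie within the scatter of each other and no order can be read from them.

Compound 3 differs from compound 1 in more than one place, and the difference between the two cores is not broken down here. What can be said is that the number for compound 3 is lower than those of compound 1 and compound 2 by more than the scatter.

Compound 4 `Cc1ccccc1N1CCN(C2=CC(=O)c3cccc(O)c3C2=O)CC1` is not yet measured. It differs from compound 3 by methyl in place of chloro on an aromatic carbon. This is the same kind of change as that from compound 1 to compound 2, but not the same: there the group sits meta to a large group, here it sits ortho to a large group.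

Because a 1.1-fold lower number from compound 1 to compound 2 (0.05 log units; within the scatter) left the number essentially unchanged, compound 4 is expected to stay close to compound 3, with an expected step of a 1.2-fold lower number from compound 3 to compound 4 (0.06 log units; within the scatter). The estimate for compound 4 in this assay is 2000 nM, expected to fall between 900 nM and 5000 nM.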

Compound 4, half-maximal inhibitory concentration: 2300 nM
The estimate for compound 4 lay 1.2-fold (0.06 log units) below the measured number; measured number inside the range.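

In this assay, putting methyl in place of chloro on an aromatic carbon, ortho to a large group, gave no change at the digits printed from compound 3 to compound 4 (within the scatter). Set beside the earlier step, the same exchange behaved alike on the two cores, and no difference between the two steps can be told apart: the same change on two cores in this assay, a 1.1-fold lower number (0.05 log units; within the scatter) from compound 1 to compound 2 and no change at the digits printed (within the scatter) from compound 3 to compound 4, 1.1-fold (0.05 log units) apart, within the scatter of two such steps

Going by these compounds alone, this shows that, in these two pairs, the exchange of chloro for methyl left the number in this cell assay within the scatter, but it does not show that the exchange would be silent on any other core or at any other place on the ring, since it rests on only two pairs, which differ from each other both in the core and in where the group sits, so the two influences cannot be separated.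

The compounds shown leave open whether a group such as methoxy, trifluoromethyl, nitrile or an amine at the same place would behave as chloro and methyl do here. They also leave open what the hydroxyl on the core of compound 3 and compound 4 contributes, as no pair shown differs in that group alone.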